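Adding a methoxy to the benzoyl side of compound 1

The compounds below may be only part of what the source reports. "The series", "measured", "known", "first", "only" and "open" are said of these compounds alone.

Going by the values given here, in a functional assay on HeLa cells (Homo sapiens) for antiproliferative activity, read by cell counting, with a stated time of 2 days (a lower number here means a stronger inhibitor, a higher number a weaker inhibitor), compound 1 (`COc1ccc(Nc2nc(N)c(C(=O)c3ccccc3)s2)cc1`) gives 230 nM, the only exact number in this small set. Compound 2 (`Nc1nc(Nc2ccc(Cl)cc2)sc1C(=O)c1ccccc1`) reads > 10000 nM, which is a limit of the assay. Compound 3 (`Nc1nc(Nc2ccc(F)cc2)sc1C(=O)c1ccccc1`) reads > 10000 nM, also a limit. Chloro in place of methoxy gives an at least 43-fold higher number from compound 1 to compound 2 (1.63 log units; beyond the scatter), and fluoro in place of methoxy gives an at least 43-fold higher number from compound 1 to compound 3 (1.63 log units; beyond the scatter). Compound 4 (`COc1ccc(Nc2nc(N)c(C(=O)c3ccccc3OC)s2)cc1`) keeps that methoxy and instead turns phenyl into 2-methoxyphenyl, with methoxy in place of hydrogen on an aromatic carbon. Those two large steps lie elsewhere in the molecule, so they bear only loosely, and a small rise in this assay is expected. The expected change is a 2.2-fold higher number from compound 1 to compound 4 (0.34 log units; beyond the scatter). For compound 4 the estimate is 500 nM, with an expected range of 80 nM to 4000 nM.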

Compound 4, half-maximal inhibitory concentration: 17 nM
Estimate against measurement, compound 4: 29-fold (1.47 log units) above; measured number outside the range, below it.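

The earlier steps shown here all lay elsewhere in the molecule, and the benzoyl ring had stayed unchanged. In this assay, methoxy in place of hydrogen on that ring, ortho to a large group, gives a 14-fold lower number from compound 1 to compound 4 (1.13 log units; beyond the scatter), so this site accepts a methoxy and the change yields a much stronger inhibitor. Nothing measured here explains the size of this gain.

From the compounds shown here alone, whether a hydroxyl, an amine or a longer chain such as ethoxy would do the same at this place stays open. So does whether this methoxy would also strengthen the chloro compound 2, whose reading is a limit.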